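The source may report more compounds than this note shows. Statements on the series, on what has been measured and on what is new or still open speak of the compounds shown alone.

Compounds measured in an assay on HEK293 cells for displacement of a labelled ligand from C-X-C chemokine receptor type 3 (Homo sapiens); a lower number here means a stronger inhibitor, a higher number a weaker inhibitor:
compound 1, `CN(CC1=CC[C@H]2C[C@@H]1C2(C)C)Cc1ccccc1I`, 5010 nM
compound 2, `CN(CC1=CC[C@H]2C[C@@H]1C2(C)C)Cc1ccc(Cl)cc1`, 2510 nM
compound 3, `CN(CC1=CC[C@H]2C[C@@H]1C2(C)C)Cc1ccc(Cl)c(Cl)c1`, 3160 nM

Among these three, compound 2 carries the lowest number, but its nearest neighbour is close: the step of a 1.3-fold higher number from compound 2 to compound 3 (0.10 log units; within the scatter) stays within the scatter, and the gap from compound 2 to compound 1 does likewise. The three numbers thus form a single band in this assay, and no order among them can be read.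

Compound 4, `CN(CC1=CC[C@H]2C[C@@H]1C2(C)C)Cc1ccc(-c2cccc(F)c2)cc1`, is not yet measured in this assay. Relative to compound 2 the change is 3-fluorophenyl in place of chloro on an aromatic carbon. Among the measured compounds shown here, the only measured step, a 1.3-fold higher number from compound 2 to compound 3 (0.10 log units; within the scatter), concerns a chloro in place of hydrogen and did not move the number beyond the scatter. For the measured compounds named here, no measured step adds a ring, so the change from chloro to 3-fluorophenyl has no precedent here, and its size and direction cannot be read from the data.

With nothing to push the expectation either way, the estimate for compound 4 is 2500 nM, within 500 nM to 12000 nM. That expected figure corresponds to a step of a 1.0-fold lower number from compound 2 to compound 4 (0.00 log units; within the scatter), that is, no step beyond the scatter, with the range kept wide since the data give no guide.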

Compound 4, inhibition constant: 2510 nM
Estimate against measurement, compound 4: 1.0-fold (0.00 log units) below; low and high end bracket the measured number.
By their numbers in this assay, from the lowest: compounds 2, 4, 3 and 1 (each within the scatter of the next).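

In this assay, chloro gives way to 3-fluorophenyl on this aromatic carbon, one heavy atom replaced by seven and a six-membered aromatic ring added, and the outcome is no change at the digits printed from compound 2 to compound 4 (within the scatter). The earlier compounds shown here showed only the addition of a single chlorine, a 1.3-fold higher number from compound 2 to compound 3 (0.10 log units; within the scatter), whereas this result shows that the position para to a large group can carry a whole extra aromatic ring and the number stays in the same band as the compounds with one or two halogens. No evidence is at hand on why the number holds for so large an exchange.

Chloro and 3-fluorophenyl both carry no hydrogen-bond donors, no hydrogen-bond acceptors and no net charge, so the compounds shown leave open whether an amine or a carboxylic acid at this position, directly or at the end of a longer chain, would move the number beyond the scatter. Also open, from the compounds shown here alone, is whether a pyridine ring in place of the 3-fluorophenyl, or a phenyl ring with the fluorine elsewhere, would take any compound out of this single band.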